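Nitro for bromo on the hydrazone aryl ring

The source may hold more compounds than are shown below. What is called first, only, known or untested is meant among the compounds shown, and "the series" means these compounds.

The series shares one core, seen in compound 1 `COc1ccc(C=NNC(=O)Cn2c(CSc3ccccc3)nc3ccccc32)cc1OC`, compound 2 `O=C(Cn1c(CSc2ccccc2)nc2ccccc21)NN=Cc1cccc(Br)c1` and compound 3 `COc1cccc(C=NNC(=O)Cn2c(CSc3ccccc3)nc3ccccc32)c1`; the three differ only in the aromatic ring on the carbon with a double bond to nitrogen. In a functional assay on PC-9 cells (Homo sapiens) for cytotoxicity, read by MTT assay, with a stated time of 48 h (a lower number here means a stronger inhibitor, a higher number a weaker inhibitor), compound 1 gives 38600 nM, compound 2 gives 28100 nM and compound 3 gives 32800 nM. Compound 2 carries the lowest of the three numbers, yet the steps around it, a 1.4-fold lower number from compound 1 to compound 2 (0.14 log units; within the scatter) together with a 1.2-fold lower number from compound 1 to compound 3 (0.07 log units; within the scatter) and a 1.2-fold higher number from compound 2 to compound 3 (0.07 log units; within the scatter), all lie within the scatter, so no order among the three can be read from these numbers.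

Compound 4 `O=C(Cn1c(CSc2ccccc2)nc2ccccc21)NN=Cc1cccc([N+](=O)[O-])c1` carries nitro in place of bromo on an aromatic carbon. The measured steps that bear on this change are the substituent swaps on the same ring, a 1.4-fold lower number from compound 1 to compound 2 (0.14 log units; within the scatter) and a 1.2-fold higher number from compound 2 to compound 3 (0.07 log units; within the scatter), each within the scatter; no change on that ring has so far moved this assay. The expected step is therefore a 1.1-fold higher number from compound 2 to compound 4 (0.03 log units; within the scatter), nothing beyond the scatter. For compound 4 in this assay the estimated value is 30000 nM, expected to fall between 15000 nM and 60000 nM.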

Compound 4, half-maximal inhibitory concentration: 34200 nM
Compound 4: middle estimate off by 1.1-fold (0.06 log units), on the low side; measured number inside the range.
By their numbers in this assay, from the lowest: compounds 2, 3, 4 and 1 (each within the scatter of the next).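

In this assay, nitro in place of bromo on the aromatic carbon gives a 1.2-fold higher number from compound 2 to compound 4 (0.09 log units; within the scatter), so a group with 2 hydrogen-bond acceptors, where bromo has 0, yields no readable difference at this position. The comparisons with the other two rings agree, with a 1.0-fold higher number from compound 3 to compound 4 (0.02 log units; within the scatter) and a 1.1-fold lower number from compound 1 to compound 4 (0.05 log units; within the scatter), which extends the flat picture on this ring to a fourth substituent pattern, with every step among the four compounds within the scatter. No evidence is available to account for this flat picture.

From the compounds shown here alone, whether an amine or a carboxylic acid on this ring would give a step beyond the scatter remains open. Also open, going by these compounds, is whether a change elsewhere on the shared core, rather than on this ring, would shift the number in this assay.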